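The source may hold more compounds than are shown below. What is called first, only, known or untested is meant among the compounds shown, and "the series" means these compounds.

Measured compounds:
compound 1 `COc1ccc2c(C3CC(c4ccncc4)=NO3)c[nH]c2c1`; in a functional assay on CWR22R cells (Homo sapiens) for inhibition, read by MTT assay, with a stated time of 48 h (on this read-out lower numbers stand for stronger inhibition and higher numbers for weaker inhibition), compound 1 gives 16300 nM.
compound 2 `c1ccc2c(C3CC(c4ccncc4)=NO3)c[nH]c2c1`; in this assay compound 2 reaches > 100000 nM, a limit rather than a number (the limit of > 100000 nM in this assay, at which 1 of the 2 values shown sits).

Compound 2 thus stands at the weak end of the two values shown, without a number of its own. Within the data shown here, the only measured step, an at least 6.1-fold higher number from compound 1 to compound 2 (0.78 log units; beyond the scatter), bears on the change to compound 3 `COc1ccc2[nH]cc(C3CC(c4ccncc4)=NO3)c2c1`: methoxy in place of hydrogen on an aromatic carbon, here at a different aromatic carbon than in compound 1. Re-entry of a methoxy is expected to lower this assay, by roughly an at least 3.3-fold lower number from compound 2 to compound 3 (0.52 log units; beyond the scatter), with the reservation that the site differs. Compound 3 is therefore estimated at 30000 nM, range 8000 nM to 100000 nM, and a limit may again be returned.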

Compound 3, half-maximal inhibitory concentration: 35500 nM
The estimate for compound 3 lay 1.2-fold (0.07 log units) below the measured number, and the stated range covers the measured number.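

In this assay, methoxy on a different aromatic carbon of the shared core, meta to a fused ring and para to a fused ring, also gives a lower number: an at least 2.8-fold lower number from compound 2 to compound 3 (0.44 log units; beyond the scatter). The effect of methoxy in place of hydrogen is therefore not confined to the site in compound 1, and the true size of this step remains unknown: the limit of > 100000 nM in this assay, at which 1 of the 3 values shown sits.

Among these compounds, compound 1 gives 16300 nM and compound 3 gives 35500 nM, with no step printed between these two sites. Open, on these data alone, is whether a hydroxyl, an amine or a longer ether such as ethoxy on either carbon would behave as methoxy does.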